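Replacing the 4-fluorophenyl group of compound 3

A few compounds are considered here, and "the series" means these few. Any claim that something is new, unique, unknown or untested is made for them only; others in the source may bear on it.

The measurements in a functional assay on MGC-803 cells (Homo sapiens) for antiproliferative activity, read by MTT assay, with a stated time of 48 h (on this read-out higher numbers stand for weaker inhibition and lower numbers for stronger inhibition), are these:
compound 1 (`COc1cc(CN(C(=O)CSc2nc3ccccc3s2)c2cc(OC)c(OC)c(OC)c2)cc(OC)c1OC`) gives 45700 nM here
compound 2 (`COc1ccc(CN(C(=O)CSc2nc3ccccc3s2)c2cc(OC)c(OC)c(OC)c2)cc1OC`) gives 34100 nM here
compound 3 (`COc1cc(N(Cc2ccc(F)cc2)C(=O)CSc2nc3ccccc3s2)cc(OC)c1OC`) gives > 80000 nM as a limit of the assay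

Compound 3 has no exact number, only a limit. Going on to compound 4 (`COc1ccc(CN(C(=O)CSc2nc3ccccc3s2)c2cc(OC)c(OC)c(OC)c2)cc1C(F)(F)F`), 4-methoxy-3-(trifluoromethyl)phenyl comes in place of 4-fluorophenyl on a saturated chain carbon bound to an amide-type nitrogen (4-methoxy-3-(trifluoromethyl)phenyl in place of 4-fluorophenyl on a saturated chain carbon bound to an amide-type nitrogen).

The measured steps that bear on this change run the opposite way, since they bring 4-fluorophenyl in. One is an at least 2.3-fold higher number from compound 2 to compound 3 (0.37 log units; beyond the scatter) and the other is an at least 1.7-fold higher number from compound 1 to compound 3 (0.24 log units; that floor lies within the scatter) and both end at the limit. Taking one methoxy away gave a 1.3-fold lower number from compound 1 to compound 2 (0.13 log units; within the scatter) and so made no clear difference. Compound 4 keeps a methoxy on that phenyl, as does compound 2 (34100 nM), so a return towards that level is expected. Going by the values given here, no measured compound carries a trifluoromethyl group, and the expectation stays loose, with another limit still possible.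

The expected change in this assay is an at least 2.0-fold lower number from compound 3 to compound 4 (0.30 log units; that floor lies within the scatter) and it points towards stronger inhibition. The estimated value for compound 4 is 40000 nM (expected range 15000 nM to 80000 nM).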

Compound 4, half-maximal inhibitory concentration: 25200 nM
For compound 4 the middle estimate is 1.6-fold (0.20 log units) above the measured one, and the stated range covers the measured number.
By their numbers in this assay, from the lowest: compounds 4, 2 and 1 (each within the scatter of the next). At a limit, above all of these: compound 3.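

On the saturated chain carbon bound to an amide-type nitrogen, 4-methoxy-3-(trifluoromethyl)phenyl replaces the 4-fluorophenyl group of compound 3 and gives an exact value in this assay, with an at least 3.1-fold lower number from compound 3 to compound 4 (0.50 log units; beyond the scatter), but compound 3 has only a limit of the assay, so this size is a floor: the limit of > 80000 nM in this assay, at which 1 of the 4 values shown sits.

This is also the first view of a trifluoromethyl group on that phenyl, and putting it in place of methoxy makes no clear difference, with a 1.4-fold lower number from compound 2 to compound 4 (0.13 log units; within the scatter), while the comparison with the 3,4,5-trimethoxyphenyl group also stays within the scatter, with a 1.8-fold lower number from compound 1 to compound 4 (0.26 log units; within the scatter). Compounds 1, 2 and 4 all keep a methoxy on that phenyl and cannot be ranked against one another, so this position accepts all three of these substituted phenyl groups with no clear difference in this assay.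

Going by these compounds, whether a trifluoromethyl group without the methoxy would hold this level remains open. So does the question of whether an amine or a carboxylic acid on that phenyl would move the number clearly away from the level shared by compounds 1, 2 and 4.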